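One aryl swap, traced across two related cores

This account rests on a few compounds, and the source may have more. Where it says the series, first, only, none or still open, it means among the compounds named here.

Compound 1 `COc1ccc(C2CC(c3ccc(NC(=O)c4cc(Cl)ccc4OC)cc3)=NN2c2ccccc2)cc1` was tested in a functional assay on the whole organism (strain albino) with Rattus norvegicus as the target, read by paw edema, with stated times of 1 h and 4 h, at a dose of 50 mg/kg by the oral route (a lower number here means a weaker effect, a higher number a stronger effect of the compound at the dose given), where compound 1 gives 98%. Compound 2 `COc1ccc(Cl)cc1C(=O)Nc1ccc(C2=NN(c3ccccc3)C(c3ccccc3[N+](=O)[O-])C2)cc1` differs from compound 1 by 2-nitrophenyl in place of 4-methoxyphenyl on a saturated ring carbon, and in this assay compound 2 gives 88.4%. That step is a number 9.6 percentage points lower from compound 1 to compound 2 (within the scatter). Compound 3 `COc1ccc(C2CC(c3ccc(NC(=O)c4cc(Cl)ccc4OC)cc3)=NN2C(C)=O)cc1` has a different core from compound 1, the difference being (acetyl in place of phenyl on an amine nitrogen in a ring), and in this assay compound 3 gives 90.2%, a step of a number 7.8 percentage points lower from compound 1 to compound 3 (within the scatter). All three measured numbers therefore sit close together, and none of them can be called the strongest or the weakest.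

Compound 4 `COc1ccc(Cl)cc1C(=O)Nc1ccc(C2=NN(C(C)=O)C(c3ccccc3[N+](=O)[O-])C2)cc1` has not yet been measured. It differs from compound 3 by 2-nitrophenyl in place of 4-methoxyphenyl on a saturated ring carbon. For the measured compounds named here, this is the same kind of change as the one from compound 1 to compound 2, but the surroundings are not identical: in compound 1 the saturated ring carbon is next to the ring atom that bears a phenyl group, whereas in compound 3 it is next to the ring atom that bears an acetyl group. The step is expected to be a number 9.2 percentage points lower from compound 3 to compound 4 (within the scatter), an expectation that rests on the earlier swap having produced a number 9.6 percentage points lower from compound 1 to compound 2 (within the scatter) and on the core of compound 3 responding like the core of compound 1, which the measured compounds cannot confirm. For compound 4 the estimated activity in this assay is 81%, with an expected range from 68% to 92%.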

Compound 4, a percentage reported as activity, at one dose (the size of the read-out at that dose, not a potency): 96.2%
For compound 4 the middle estimate is 15.2 percentage points below the measured one, outside the stated range (above it).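

In this assay, 2-nitrophenyl in place of 4-methoxyphenyl on a saturated ring carbon gives a number 6 percentage points higher from compound 3 to compound 4 (within the scatter), and this step does not match the one seen with the phenyl group on the ring nitrogen: the same change on two cores in this assay, a number 9.6 percentage points lower (within the scatter) from compound 1 to compound 2 and a number 6 percentage points higher (within the scatter) from compound 3 to compound 4, 15.6 percentage points apart, beyond the scatter of two such steps. Read the other way round, acetyl in place of phenyl on an amine nitrogen in a ring gives a number 7.8 percentage points higher from compound 2 to compound 4 (within the scatter), and this change does not carry over from one partner to the other either: the same change on two cores in this assay, a number 7.8 percentage points lower (within the scatter) from compound 1 to compound 3 and a number 7.8 percentage points higher (within the scatter) from compound 2 to compound 4, 15.6 percentage points apart, beyond the scatter of two such steps. Together these show that, in this set, neither change can be moved to the other core as a fixed step, but each single step lies within the scatter, and both gaps come from the same four compounds, so they are one finding rather than two and give no reason for the mismatch.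

From the compounds shown here alone, it remains open whether the same mismatch would appear with other groups on the saturated ring carbon, such as 4-aminophenyl or 4-carboxyphenyl, or with a propanoyl group in place of acetyl on the ring nitrogen. Going by these compounds, it is also open whether a second pair of aryl groups on these two cores would repeat the result or bring the two steps back into line.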